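The source may hold more compounds than are shown below. What is called first, only, known or untested is meant among the compounds shown, and "the series" means these compounds.

Measured so far in a functional assay on HEp-2 cells (Homo sapiens) for cytotoxicity, read by MTT assay; on this read-out lower numbers stand for stronger inhibition and higher numbers for weaker inhibition:

- compound 1, `COc1ccc2[nH]c(-c3ccccc3)c(C(c3c(-c4ccccc4)[nH]c4ccc(C)cc34)C3C(=O)NN=C3C)c2c1`: 3500 nM
- compound 3, `COc1ccc2[nH]c(-c3ccccc3)c(C(c3c[nH]c4ccccc34)C3C(=O)NN=C3C)c2c1`: 5300 nM
- compound 2, `CC1=NNC(=O)C1C(c1c(-c2ccccc2)[nH]c2ccccc12)c1c(-c2ccccc2)[nH]c2ccc(C)cc12`: a value that is a limit of this assay and not a number, > 100000 nM

Among the compounds with values here, the only single-point step measured is the one from compound 1 to compound 2, (hydrogen in place of methoxy on an aromatic carbon), which brings an at least 28-fold higher number from compound 1 to compound 2 (1.45 log units; beyond the scatter). Part of that size rests on (the limit of > 100000 nM in this assay, at which 1 of the 3 values shown sits), so the step is known only as a lower bound. Compound 3 differs from compound 1 in its core; that difference is not broken down here, and the two values lie within the scatter of each other.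

Compound 4, `CC1=NNC(=O)C1C(c1c[nH]c2ccccc12)c1c(-c2ccccc2)[nH]c2ccccc12`, is not yet measured. It stands to compound 3 as compound 2 stands to compound 1: hydrogen in place of methoxy on an aromatic carbon, the same change at the same place. Within the data shown here, on the strength of the one measured step, a large loss in this assay is expected here too, and the estimated step is a 15-fold higher number from compound 3 to compound 4 (1.18 log units; beyond the scatter). Compound 4 is accordingly expected to give about 80000 nM in this assay, with a fair chance that only a limit is reported.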

Compound 4, half-maximal inhibitory concentration: 6700 nM
Beside the measured number, compound 4's estimate is 12-fold (1.08 log units) above it, outside the stated range (below it).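

In this assay, hydrogen in place of methoxy on an aromatic carbon brings a 1.3-fold higher number from compound 3 to compound 4 (0.10 log units; within the scatter). Set beside the earlier step, this shows that the outcome of the change does not carry over from one core to the other: the same change on two cores in this assay, an at least 28-fold higher number (1.45 log units; beyond the scatter) from compound 1 to compound 2 and a 1.3-fold higher number (0.10 log units; within the scatter) from compound 3 to compound 4, at least 22-fold (1.35 log units) apart, beyond the scatter of two such steps

Compound 2 carries a limit and not a number, so the earlier step is only a lower bound, and these two pairs show neither what makes the outcome depend on the core nor what the change would do on a third core: the limit of > 100000 nM in this assay, at which 1 of the 4 values shown sits.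

Only methoxy and hydrogen stand at this place in the compounds shown, so the outcome with a hydroxyl group, a chlorine atom or a longer chain such as ethoxy remains open. Also open, on these data alone, is which of the differences between the core of compound 1 and the core of compound 3 governs the size of the step.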